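From Hydroxy to Phenoxy: Expected Growth Inhibition of Compound 3

The source may hold more compounds than are shown below. What is called first, only, known or untested is meant among the compounds shown, and "the series" means these compounds.

Compound 1 `CC1=C(C(=O)Nc2ccc(Cl)c(Cl)c2)C(c2cccc(O)c2)NC(=S)N1` — 15800 nM
Compound 2 `CC1=C(C(=O)Nc2ccc(Cl)c(Cl)c2)C(c2cccc(Cl)c2)NC(=O)N1` — 11200 nM

Among the measured compounds shown here, in a functional assay on SF-268 cells (Homo sapiens) for cytotoxicity, read by sulforhodamine B assay, with a stated time of 48 h (a higher number here means a weaker inhibitor of growth, a lower number a stronger inhibitor of growth), compound 1 gives 15800 nM, the higher of the two numbers measured so far. Compound 2 gives 11200 nM, and the two values lie within the scatter of each other. Compound 3 `CC1=C(C(=O)Nc2ccc(Cl)c(Cl)c2)C(c2cccc(Oc3ccccc3)c2)NC(=S)N1` differs from compound 1 by phenyl in place of hydrogen on an oxygen on an aromatic ring. For the measured compounds named here, no measured pair in this set shows this change, so its effect cannot be read from the data. The step of a 1.4-fold lower number from compound 1 to compound 3 (0.16 log units; within the scatter) is expected to be small, not beyond the scatter, with no clear direction. Compound 3 is therefore estimated to give 11000 nM, within a range from 3000 nM to 40000 nM.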

Compound 3, concentration for 50% growth inhibition: 6170 nM
Beside the measured number, compound 3's estimate is 1.8-fold (0.25 log units) above it; the measured number falls inside the stated range.
By their numbers in this assay, from the lowest: compounds 3, 2 and 1 (each within the scatter of the next, the first and the last beyond it).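

In this assay, phenyl in place of hydrogen on the oxygen gives a 2.6-fold lower number from compound 1 to compound 3 (0.41 log units; beyond the scatter) and so a modest step beyond the scatter. Among the compounds shown here, the earlier compounds offered no pair differing in one place, and this step is the first to show that this position accepts an added aromatic ring and that the hydroxy hydrogen is not needed for growth inhibition. Nothing available here explains the step.

The compounds shown leave open whether a methyl or a longer chain on this oxygen would lower the number as well. They also leave open whether the phenyl ring itself matters, or how an amine or a carboxylic acid on that ring would read.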